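Sulfamoyl in place of methylsulfonyl on a shared amide core

The source may report more compounds than this note shows. Statements on the series, on what has been measured and on what is new or still open speak of the compounds shown alone.

Measured so far:
compound 1, `COc1cc(C)c(S(N)(=O)=O)cc1C(=O)Nc1cccc(-c2nncn2C(C)C)n1`, 1%
compound 2, `COc1ccc(S(C)(=O)=O)cc1C(=O)Nc1cccc(-c2nncn2C(C)C)n1`, 2%

In an assay for inhibition of serine/threonine-protein kinase Sgk1 (Homo sapiens), tested at 1 uM (on this read-out lower numbers stand for less inhibition and higher numbers for more inhibition at the one concentration tested (going by the name of the read-out)), compound 2 gives 2%, and compound 1 gives 1%, a gap within the scatter, so neither can be ranked above the other. Compound 3, `COc1ccc(S(N)(=O)=O)cc1C(=O)Nc1cccc(-c2nncn2C(C)C)n1`, has not yet been measured. It differs from compound 2 by amino in place of methyl on a sulfonyl sulfur. Compound 1 already carries a sulfamoyl group and shows weak inhibition, so no step beyond the scatter is expected: the estimated step of no change at the digits printed from compound 2 to compound 3 (within the scatter) is essentially flat. Compound 3 is estimated at 2%, with a range from 0% to 12%.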

Compound 3, a percentage reported as inhibition, at one concentration (the size of the read-out at that concentration, not a potency) in the serine/threonine-protein kinase Sgk1 assay: -12%
Estimate against measurement, compound 3: 14 percentage points above; the whole stated range lies above it.
By their numbers in the serine/threonine-protein kinase Sgk1 assay, from the lowest: compound 3; then compounds 1 and 2 (each within the scatter of the next).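

In the serine/threonine-protein kinase Sgk1 assay amino in place of methyl on a sulfonyl sulfur gives a number 14 percentage points lower from compound 2 to compound 3 (beyond the scatter) and hydrogen in place of methyl on an aromatic carbon gives a number 13 percentage points lower from compound 1 to compound 3 (beyond the scatter). Compound 1 carries the same sulfamoyl group yet stands with compound 2, so the sulfamoyl group alone does not set the number. In a physicochemical assay for solubility, measured as thermodynamic solubility, at pH 7.4 (on this read-out higher numbers stand for higher solubility and lower numbers for lower solubility), compound 2 gives 5000 nM and compound 3 gives 1200 nM and the change to sulfamoyl thus lowers solubility: the measured solubility of compound 2, 5000 nM, and of compound 3, 1200 nM, a 4.2-fold lower number (0.62 log units; beyond the scatter). Still open, from the compounds shown here alone, is whether a dimethylamino group on the sulfonyl sulfur, or an ethyl group or chlorine in place of that aromatic methyl, would bring any real inhibition.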